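A few compounds are considered here, and "the series" means these few. Any claim that something is new, unique, unknown or untested is made for them only; others in the source may bear on it.

Compound 1 `CCN1CCN(C(=S)SCC(=O)N(Cc2ccc(OC)cc2)c2cc(OC)c(OC)c(OC)c2)CC1`: 7700 nM
Compound 2 `COc1ccc(CN(C(=O)CSC(=S)N2CCN(C(=O)OC(C)(C)C)CC2)c2cc(OC)c(OC)c(OC)c2)cc1O`: 128 nM
Compound 3 `COc1ccc(CN(C(=O)CSC(=S)N2CCN(C)CC2)c2cc(OC)c(OC)c(OC)c2)cc1O`: 810 nM

All three values come from a functional assay on HCT-116 cells (Homo sapiens) for inhibition, read by CCK-8 assay, with a stated time of 48 h; on this read-out higher numbers stand for weaker inhibition and lower numbers for stronger inhibition. Compound 3 holds the middle place of the three: its number is higher than that of compound 2 and lower than that of compound 1.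

Compound 4 `CCN1CCN(C(=S)SCC(=O)N(Cc2ccc(OC)c(O)c2)c2cc(OC)c(OC)c(OC)c2)CC1` is compound 3 with one small addition, (methyl in place of hydrogen on a saturated chain carbon bound to an amine nitrogen in a ring). Put simply, a methyl group takes the place of a hydrogen on a saturated chain carbon bound to an amine nitrogen in a ring, turning 4-methylpiperazin-1-yl into 4-ethylpiperazin-1-yl.

Within the data shown here, only one measured step changes the group on this ring nitrogen: a 6.3-fold higher number from compound 2 to compound 3 (0.80 log units; beyond the scatter). That step was modest but beyond the scatter, and it exchanged tert-butoxycarbonyl for methyl, a much larger change than the one considered here. Compound 1 also carries 4-ethylpiperazin-1-yl and gives 7700 nM, but it differs from compound 4 elsewhere, so it cannot show the effect of this change alone. Among the measured compounds shown here, no measured pair isolates methyl to ethyl.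

With so small a change, no shift beyond the scatter is expected. The expected step, a 1.1-fold lower number from compound 3 to compound 4 (0.03 log units; within the scatter), is an estimate that stays within that scatter. For compound 4, the estimated value is 750 nM, with an expected range of 300 nM to 1900 nM.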

Compound 4, half-maximal inhibitory concentration: 530 nM
Compound 4: middle estimate off by 1.4-fold (0.15 log units), on the high side, within the range that was stated.
By their numbers in this assay, from the lowest: compound 2; then compounds 4 and 3 (each within the scatter of the next); then compound 1.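

In this assay, the step of a 1.5-fold lower number from compound 3 to compound 4 (0.18 log units; within the scatter) shows that extending the group on the ring nitrogen from methyl to ethyl makes no difference that can be told from the scatter, so 4-methylpiperazin-1-yl and 4-ethylpiperazin-1-yl read alike on this core. That gives the earlier ethyl compound a clearer reading: the step of a 15-fold lower number from compound 1 to compound 4 (1.16 log units; beyond the scatter) is large and comes from a single change, hydroxy in place of hydrogen on an aromatic carbon. The step of a 4.1-fold higher number from compound 2 to compound 4 (0.62 log units; beyond the scatter) lies beyond the scatter and points the same way as a 6.3-fold higher number from compound 2 to compound 3 (0.80 log units; beyond the scatter) does, so with either small alkyl group the number stays higher than with tert-butoxycarbonyl on this nitrogen. No measurement shown gives a cause for any of these steps.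

As far as these compounds go, whether the trend stays flat with a longer chain such as propyl, or with a bare hydrogen or an acetyl group on this nitrogen, remains open. So does whether the hydroxy step keeps its size with tert-butoxycarbonyl or methyl on the ring nitrogen, and whether a fluorine at that aromatic carbon would serve as well.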